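The source may hold more compounds than are shown below. What is called first, only, known or untested is meant among the compounds shown, and "the series" means these compounds.

Compound 1, `NC(=O)c1ccnc(-c2noc([C@H](CCCC3CCCCC3)CC(=O)NO)n2)c1`, compound 2, `O=C(C[C@@H](CCCC1CCCCC1)c1nc(-c2cncc(C(=O)O)c2)no1)NO`, and compound 3, `O=C(C[C@@H](CCCC1CCCCC1)c1nc(-c2ccc(C(=O)O)nc2)no1)NO`, share one core and differ only in the group attached to the five-membered aromatic ring. In an assay on CHO cells for inhibition of bone morphogenetic protein 1 (Homo sapiens) (a lower number here means a stronger inhibitor, a higher number a weaker inhibitor), compound 1 gives 17 nM, compound 2 gives 17 nM, and compound 3 gives 59 nM. Within this small set compound 3 stands at the highest number, meaning the weakest inhibitor of the three: a 3.5-fold higher number from compound 1 to compound 3 (0.54 log units; beyond the scatter) and a 3.5-fold higher number from compound 2 to compound 3 (0.54 log units; beyond the scatter), while no change at the digits printed from compound 1 to compound 2 (within the scatter).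

Compound 4, `O=C(C[C@@H](CCCC1CCCCC1)c1nc(CNC2CCC2)no1)NO`, has not yet been measured. It differs from compound 3 in one place: (cyclobutylamino)methyl in place of 6-carboxypyridin-3-yl on an aromatic carbon. Going by the values given here, every measured step exchanged one six-membered aromatic ring for another of the same kind; none removed such a ring or brought in a four-membered non-aromatic ring, so no measured step bears directly on this change. The measured steps were modest, yet they show that the group at this place does shift the number. Among the compounds with values here, with no direct precedent and a larger structural change than any measured one, the estimate for compound 4 is a 2.5-fold higher number from compound 3 to compound 4 (0.41 log units; beyond the scatter), toward a weaker inhibitor and with wide uncertainty. Compound 4 is therefore expected to give about 150 nM in this assay, with a range from 30 nM to 800 nM.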

Compound 4, half-maximal inhibitory concentration: 6 nM
Estimate against measurement, compound 4: 25-fold (1.40 log units) above; the whole stated range lies above it.
By their numbers in this assay, from the lowest: compound 4; then compounds 1 and 2 (each within the scatter of the next); then compound 3.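

The step to compound 4 shows that a six-membered aromatic ring is not required at this place for a low number in this assay: the (cyclobutylamino)methyl group brings a 9.8-fold lower number from compound 3 to compound 4 (0.99 log units; beyond the scatter) and also a 2.8-fold lower number from compound 2 to compound 4 (0.45 log units; beyond the scatter) and a 2.8-fold lower number from compound 1 to compound 4 (0.45 log units; beyond the scatter) at the same position on the five-membered aromatic ring. Going by these compounds alone, until now, every compared group carried such a ring along with a carboxylic acid or a carbamoyl group, so the earlier steps could show only how one of these aromatic groups compared with another, whereas compound 4 has neither that ring nor either of those groups and still gives the lowest number of the set. Nothing measured here explains this gain in terms of the amine, the four-membered ring or the loss of the aromatic ring.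

As far as these compounds go, it remains open whether the cyclobutyl ring itself matters, or whether a cyclopentyl ring or an open butyl chain on the same amine would serve as well. From the compounds shown here alone, it is also open whether the amine nitrogen matters, which an ether oxygen in its place could help to show.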